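Adding a bromo to the phenyl ring of compound 2

The source may hold more compounds than are shown below. What is called first, only, known or untested is meant among the compounds shown, and "the series" means these compounds.

In a functional assay on A-375 cells (Homo sapiens) for antiproliferative activity, read by MTT assay, with a stated time of 48 h (a higher number here means a weaker inhibitor, a lower number a stronger inhibitor), compound 1 `O=C(Nc1cc(-c2ccccc2)[nH]n1)c1cccnc1F` gives 4880 nM and compound 2 `COc1ncccc1C(=O)Nc1cc(-c2ccccc2)[nH]n1` gives 9940 nM. Compound 2 therefore has the higher of the two numbers and is the weaker inhibitor. Compound 3 `COc1ncccc1C(=O)Nc1cc(-c2ccc(Br)cc2)[nH]n1` keeps compound 2 unchanged except for one edit, phenyl to 4-bromophenyl: bromo in place of hydrogen on an aromatic carbon, para to a large group (bromo in place of hydrogen on an aromatic carbon). Going by the values given here, the only measured step, a 2.0-fold higher number from compound 1 to compound 2 (0.31 log units; beyond the scatter), is modest and comes from methoxy in place of fluoro at a different place in the molecule. It therefore offers only a rough sense of size and no direct guide to this edit. A modest move towards a lower number seems likely, although the data cannot settle the direction. The expected change is a 2.2-fold lower number from compound 2 to compound 3 (0.34 log units; beyond the scatter). Compound 3 is estimated at 4500 nM, within a range of 1500 nM to 12000 nM.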

Compound 3, half-maximal inhibitory concentration: 11100 nM
Compound 3: the middle estimate sits 2.5-fold (0.39 log units) below what was measured, within the range that was stated.
By their numbers in this assay, from the lowest: compound 1; then compounds 2 and 3 (each within the scatter of the next).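

In this assay, adding a bromo to the phenyl ring, para to a large group, gives a 1.1-fold higher number from compound 2 to compound 3 (0.05 log units; within the scatter), so compound 2 and compound 3 cannot be told apart. Going by these compounds alone, the earlier step showed only that the number can respond to an edit elsewhere in the molecule; this one shows that, with the methoxy in place, adding one bromine atom at this aromatic carbon leaves no readable mark on the antiproliferative result. No supporting measurement is available to explain this outcome.

The compounds shown leave open whether an amine or a carboxylic acid at this same position would move the number beyond the scatter. They also leave open whether the bromo would give the same result when paired with the fluoro of compound 1 rather than the methoxy.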